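The compounds below may be only part of what the source reports. "The series", "measured", "known", "first", "only" and "open" are said of these compounds alone.

Working notes on the series. Compound 1 `[O-][S+](CCNC1CCN(Cc2ccc(F)cc2)CC1)C(c1ccc(F)cc1)c1ccc(F)cc1` holds the lower of the two numbers obtained so far; in an assay on membranes from striatum (strain Sprague-Dawley) for displacement of a labelled ligand from sodium-dependent dopamine transporter (Rattus norvegicus), read by scintillation counting, with a stated time of 120 min (a lower number here means a stronger inhibitor, a higher number a weaker inhibitor), compound 1 gives 50.6 nM. Compound 2 `Fc1ccc(C(SCCNC2CCN(Cc3cc4ccccc4[nH]3)CC2)c2ccc(F)cc2)cc1` carries a different group on the same ring nitrogen, and in this assay compound 2 gives 179 nM; the gap between these two values lies beyond the scatter, with compound 1 at the lower number. Going by the values given here, no pair of measured compounds differing in only one place is available, so the effect of changing the group on that ring nitrogen on its own has not been isolated.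

Compound 3 `O=C(c1ccc(F)cc1F)N1CCC(NCC[S+]([O-])C(c2ccc(F)cc2)c2ccc(F)cc2)CC1` has not been measured. It differs from compound 1 in one place: (2,4-difluorophenyl)carbonyl in place of 4-fluorobenzyl on an amine nitrogen in a ring. Among the compounds with values here, the only guide is that compound 2, which also differs from compound 1 at that nitrogen, shows the higher number. On that basis a step from compound 1 to compound 3 toward a weaker inhibitor is expected, and it is estimated to be of moderate size, a 3.2-fold higher number from compound 1 to compound 3 (0.50 log units; beyond the scatter). Compound 3 is therefore expected to give 160 nM in this assay, within an estimated range from 45 nM to 600 nM.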

Compound 3, inhibition constant: 564 nM
For compound 3 the middle estimate is 3.5-fold (0.55 log units) below the measured one; the measured number falls inside the stated range.
By their numbers in this assay, from the lowest: compound 1; then compound 2; then compound 3.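

Going by these compounds alone, this is the first step that isolates the group on this ring nitrogen: in this assay, replacing 4-fluorobenzyl with (2,4-difluorophenyl)carbonyl while the rest of compound 1 stays unchanged gives an 11-fold higher number from compound 1 to compound 3 (1.05 log units; beyond the scatter), a large step beyond the scatter. The position is therefore sensitive to the nature of its substituent, and keeping one six-membered aromatic ring of carbon only in the incoming group does not preserve the number seen for compound 1. No measurement available here bears on the reason for this loss, so the step stands as an observation only.

The change alters more than one feature at once, introducing a carbonyl in place of the benzyl carbon and altering the fluorine substitution on the aromatic ring, so the share of each in the step remains unresolved. A 2,4-difluorobenzyl group or a (4-fluorophenyl)carbonyl group on the same nitrogen would separate the two, while a simple alkyl group such as methyl would show how much the aromatic ring itself contributes.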